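The source may report more compounds than this note shows. Statements on the series, on what has been measured and on what is new or still open speak of the compounds shown alone.

In a functional assay on Daudi cells (Homo sapiens) for antiproliferative activity (a higher number here means a weaker inhibitor, a lower number a stronger inhibitor), compound 1 (`Nc1ncnc2c1c(-c1ccc(Oc3ccccc3)cc1)cn2C[C@H]1CCCN1C[C@@H](O)CO`) gives 14400 nM as the highest of the three numbers at hand. Compound 3 (`CC(C)(C)c1ccc(COc2ccc(-c3cn([C@H]4CCN(C[C@@H]5CO5)C4)c4ncnc(N)c34)cc2)cc1`) gives 6970 nM and compound 2 (`Nc1ncnc2c1c(-c1ccc(C(=O)Nc3ccc(Oc4ccccc4)cc3)cc1)cn2[C@H]1CCN(C[C@@H]2CO2)C1`) gives 4390 nM with each gap to compound 1 beyond the scatter. Compound 4 (`Nc1ncnc2c1c(-c1ccc(Oc3ccccc3)cc1)cn2C[C@H]1CCCN1C(CO)CO`) is still unmeasured and differs from compound 1 in one place (2-hydroxy-1-(hydroxymethyl)ethyl in place of 2,3-dihydroxypropyl on an amine nitrogen in a ring) where 2-hydroxy-1-(hydroxymethyl)ethyl stands in place of 2,3-dihydroxypropyl on an amine nitrogen in a ring. Going by the values given here, the same atoms are only joined differently, and no measured pair shows this kind of change. In this assay no step beyond the scatter is therefore expected, and no firm direction. The expected step reads a 1.1-fold lower number from compound 1 to compound 4 (0.04 log units; within the scatter) on this estimate. For compound 4 the estimated value is 13000 nM with an expected range from 5500 nM to 30000 nM in this estimate.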

Compound 4, half-maximal inhibitory concentration: 28200 nM
Beside the measured number, compound 4's estimate is 2.2-fold (0.34 log units) below it; measured number inside the range.
By their numbers in this assay, from the lowest: compounds 2 and 3 (each within the scatter of the next); then compounds 1 and 4 (each within the scatter of the next).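

In this assay, exchanging 2,3-dihydroxypropyl for 2-hydroxy-1-(hydroxymethyl)ethyl on the amine nitrogen in the ring gives a 2.0-fold higher number from compound 1 to compound 4 (0.29 log units; within the scatter). Going by these compounds alone, this is the first step here between compounds that differ in one place, and it shows that joining the same atoms differently at this position leaves compound 1 and compound 4 indistinguishable in this read-out. Nothing at hand offers an explanation for this result. What the compounds shown leave open is whether a different group on this nitrogen, such as a carboxylic acid or a longer chain, would give a step beyond the scatter. Also open, from the compounds shown here alone, is whether the defined stereocentre of the 2,3-dihydroxypropyl group matters.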